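The source may hold more compounds than are shown below. What is called first, only, known or untested is meant among the compounds shown, and "the series" means these compounds.

Going by the values given here, compound 1 `CC(=O)OCCO[C@H](CC=C(C)C)C1=CC(=O)c2c(O)ccc(O)c2C1=O` is one of two compounds measured so far in a functional assay on HeLa cells (Homo sapiens) for cytotoxicity, read by MTT assay; on this read-out higher numbers stand for weaker inhibition and lower numbers for stronger inhibition. In this assay compound 1 gives 41500 nM, while compound 2 `CCC(C)(O)CC(=O)O[C@H](CC=C(C)C)C1=CC(=O)c2c(O)ccc(O)c2C1=O` gives 25200 nM; the step of a 1.6-fold lower number from compound 1 to compound 2 (0.22 log units; within the scatter) is within the scatter. Compound 3 `CC(C)=CC[C@@H](OC[C@H](C)O)C1=CC(=O)c2c(O)ccc(O)c2C1=O` differs from compound 1 by 1-hydroxyethyl in place of acetoxymethyl on a saturated chain carbon bound to an oxygen on a saturated carbon. Among the compounds with values here, no measured step exchanges one group for another at this place, and the only known step, from compound 1 to compound 2, alters the same side chain without moving beyond the scatter. Compound 3 is therefore expected to show a step of a 1.2-fold lower number from compound 1 to compound 3 (0.07 log units; within the scatter), with an estimated 35000 nM in this assay, within 15000 nM to 80000 nM.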

Compound 3, half-maximal inhibitory concentration: 40300 nM
Estimate against measurement, compound 3: 1.2-fold (0.06 log units) below, within the range that was stated.
By their numbers in this assay, from the lowest: compounds 2, 3 and 1 (each within the scatter of the next).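

In this assay, 1-hydroxyethyl in place of acetoxymethyl gives a 1.0-fold lower number from compound 1 to compound 3 (0.01 log units; within the scatter) and so takes the side chain from no hydrogen-bond donor to one without leaving the scatter. The other new comparison gives a 1.6-fold higher number from compound 2 to compound 3 (0.20 log units; within the scatter) and is also within the scatter, so all three side chains shown remain indistinguishable on this read-out. Nothing available explains this result. Still open, as far as these compounds go, is whether an amine or a carboxylic acid at this place, or a longer chain, would move the number beyond the scatter.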